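A Methyl Step Carried Over to a Second Core

The source may report more compounds than this note shows. Statements on the series, on what has been measured and on what is new or still open speak of the compounds shown alone.

compound 1 `O=C1N/C(=N/c2csc(-c3ccc(Cl)cc3)c2)S/C1=C\c1ccccc1`: 11200 nM
compound 2 `Cc1ccc(/C=C2\S/C(=N\c3csc(-c4ccc(Cl)cc4)c3)NC2=O)cc1`: 1000 nM
compound 3 `COc1cccc(N2C(=O)CS/C2=N\c2csc(-c3ccccc3)c2)c1`: "not determined" (no result reported)

In a functional assay on HCT-116 cells (Homo sapiens) for cytotoxicity, read by MTT assay, with a stated time of 72 h (on this read-out higher numbers stand for weaker inhibition and lower numbers for stronger inhibition), compound 1 gives 11200 nM and compound 2 gives 1000 nM. The step of an 11-fold lower number from compound 1 to compound 2 (1.05 log units; beyond the scatter) accompanies the change (methyl in place of hydrogen on an aromatic carbon). Compound 3 has no number in this assay, and the difference between its core and the core of compound 1 is not broken down here. Compound 4 `COc1cccc(N2C(=O)CS/C2=N\c2csc(-c3ccc(C)cc3)c2)c1` differs from compound 3 by methyl in place of hydrogen on an aromatic carbon, the same change at the same kind of place. Among the compounds with values here, because the only measured instance is an 11-fold lower number from compound 1 to compound 2 (1.05 log units; beyond the scatter) on a different core, and compound 3 itself is unmeasured, the expectation for compound 4 is loose. Compound 4 is expected to give about 5000 nM in this assay, with a range from 500 nM to 50000 nM.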

Compound 4, half-maximal inhibitory concentration: 41000 nM
For compound 4 the middle estimate is 8.2-fold (0.91 log units) below the measured one; the range from low to high includes it.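

Within the data shown here, compound 3 has no single number in this assay, so no step from compound 3 to compound 4 can be read. What the methyl change does on this second core stays open, and nothing shown here speaks to a cause.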